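A few compounds are considered here, and "the series" means these few. Any claim that something is new, unique, unknown or untested is made for them only; others in the source may bear on it.

Compound 1 `Cc1ccc2[nH]c(-c3cn(-c4ccccc4)nc3-c3ccccc3)nc2c1`: 5940 nM
Compound 2 `COc1ccc(-c2nn(-c3ccccc3)cc2-c2nc3cc(Br)ccc3[nH]2)cc1`: 1830 nM

In a functional assay on MCF7 cells (Homo sapiens) for antiproliferative activity, read by MTT assay, with a stated time of 48 h (a lower number here means a stronger inhibitor, a higher number a weaker inhibitor), compound 2 gives 1830 nM, the lower of the two numbers and so the stronger result. Compound 1 gives 5940 nM, and the gap between the two lies beyond the usual scatter. These compounds differ in more than one place, so their gap cannot be assigned to any single structural feature.

The next compound to be tested is compound 3 `COc1ccc(-c2nn(-c3ccccc3)cc2-c2nc3cc(C)ccc3[nH]2)cc1`. It has methyl in place of bromo on an aromatic carbon. Going by the values given here, no measured pair shows this swap alone, so its size in this assay remains a judgement. One weak clue is that compound 1, which also carries a methyl group, gives 5940 nM. A small move towards a higher number therefore seems more likely than a gain, and it may not exceed the scatter. The expected change is a 1.6-fold higher number from compound 2 to compound 3 (0.21 log units; within the scatter). The estimated value for compound 3 is 3000 nM, with an expected range from 1200 nM to 7500 nM.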

Compound 3, half-maximal inhibitory concentration: 6610 nM
Estimate against measurement, compound 3: 2.2-fold (0.34 log units) below, and the stated range covers the measured number.
By their numbers in this assay, from the lowest: compound 2; then compounds 1 and 3 (each within the scatter of the next).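

In this assay the swap of bromo for methyl gives a 3.6-fold higher number from compound 2 to compound 3 (0.56 log units; beyond the scatter) with the methoxy group held constant, so this aromatic carbon of the fused two-ring system is not indifferent to what it carries, at least for these two groups. The other one-place comparison gives a 1.1-fold higher number from compound 1 to compound 3 (0.05 log units; within the scatter) with the methyl held constant, so adding methoxy in place of hydrogen on an aromatic carbon produces no change beyond the usual scatter, in contrast to the bromo-to-methyl swap. The data offer no independent measurement that explains why bromo gives the lower number here.

The compounds shown leave open whether bromo would keep its advantage over methyl without the methoxy group, since that swap has been read only once, on a single background. They also leave open how this position would respond to other groups, such as chloro, an amine, a carboxylic acid or a longer chain, and so whether bromo is a special case or one point on a wider trend.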